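Two aryl piperazines and a difluorophenyl variant at the adenosine receptor

This account rests on a few compounds, and the source may have more. Where it says the series, first, only, none or still open, it means among the compounds named here.

Compound 1, `Nc1scc(CN2CCN(c3ccccc3C(F)(F)F)CC2)c1C(=O)c1ccc(Cl)cc1`: -7.5%
Compound 2, `Nc1scc(CN2CCN(c3ccc(C(F)(F)F)cc3)CC2)c1C(=O)c1cccc(C(F)(F)F)c1`: -11%

In a functional assay on CHO cells with adenosine receptor A1 (Homo sapiens) as the target, read by cAMP accumulation and immunoassay, with a stated time of 6 min, tested at 0.1 uM (a higher number here means a weaker effect of the compound at the concentration tested, a lower number a stronger effect), compound 1 gives -7.5%, and compound 2 gives -11%. The two numbers sit within the usual scatter of each other, so neither can be placed above the other; both show a weak effect at this concentration. Going by the values given here, no step between measured compounds is given.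

Compound 3, `Nc1scc(CN2CCN(c3cc(F)ccc3F)CC2)c1C(=O)c1ccc(Cl)cc1`, has not been measured. It differs from compound 1 in one place: 2,5-difluorophenyl in place of 2-(trifluoromethyl)phenyl on an amine nitrogen in a ring. Among the compounds with values here, with no measured step to lean on, the change is expected to move this assay by no more than the scatter, in no clear direction, so the step of a number 0.5 percentage points lower from compound 1 to compound 3 (within the scatter) is an estimate of little movement. Compound 3 is therefore expected to give about -8%, with a range from -20% to 5%.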

Compound 3, a percentage reported as activity, at one concentration (the size of the read-out at that concentration, not a potency): -13%
Compound 3: middle estimate off by 5 percentage points, on the high side; low and high end bracket the measured number.
By their numbers in this assay, from the lowest: compounds 3, 2 and 1 (each within the scatter of the next).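

Going by these compounds alone, putting 2,5-difluorophenyl in place of 2-(trifluoromethyl)phenyl on an amine nitrogen in a ring gives the first single-place comparison at this position, and in this assay it amounts to a number 5.5 percentage points lower from compound 1 to compound 3 (within the scatter). This position therefore accepts the change without a step that can be told from the scatter. No measurement at hand bears on this result.

As far as these compounds go, whether a non-aromatic group in this place, such as a carboxylic acid or a longer chain, would move the number beyond the scatter remains open. Potency also remains open, since the read-out comes from one concentration.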